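Trifluoromethyl on the phenyl group of compound 2

The compounds below may be only part of what the source reports. "The series", "measured", "known", "first", "only" and "open" are said of these compounds alone.

Going by the values given here, in a functional assay on A549 cells (Homo sapiens) for inhibition, read by CCK-8 assay, with a stated time of 48 h (a lower number here means a stronger inhibitor, a higher number a weaker inhibitor), compound 1 `COc1cc(-c2ccnc3cc(-c4c[nH]c5ccccc45)nn23)cc(OC)c1OC` gives 29 nM and compound 2 `COc1cc(-c2ccnc3cc(-c4ccccc4)nn23)cc(OC)c1OC` gives 208 nM, so compound 2 holds the higher of the two numbers so far and is the weaker inhibitor of the pair. Compound 3 `COc1cc(-c2ccnc3cc(-c4ccc(C(F)(F)F)cc4)nn23)cc(OC)c1OC` has not yet been measured in this assay. It differs from compound 2 by trifluoromethyl in place of hydrogen on an aromatic carbon, para to a large group (trifluoromethyl in place of hydrogen on an aromatic carbon), which turns phenyl into 4-(trifluoromethyl)phenyl.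

Among the compounds with values here, one measured step bears on this, and only loosely. With phenyl in place of 1H-indol-3-yl, a 7.2-fold higher number from compound 1 to compound 2 (0.86 log units; beyond the scatter) is a modest change that lies beyond the scatter. Within the data shown here, that step swaps the whole group, whereas no measured step adds a substituent to the phenyl ring, so the direction remains poorly defined. The expected step, a 1.3-fold higher number from compound 2 to compound 3 (0.10 log units; within the scatter), is smaller than the measured one, slightly upward, and may stay within the scatter. For compound 3 the estimated value is 260 nM, with an expected range from 80 nM to 850 nM.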

Compound 3, half-maximal inhibitory concentration: 2070 nM
Estimate against measurement, compound 3: 8.0-fold (0.90 log units) below, and the stated range ends below it.
By their numbers in this assay, from the lowest: compound 1; then compound 2; then compound 3.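

In this assay, trifluoromethyl in place of hydrogen on the aromatic carbon para to a large group gives a 10-fold higher number from compound 2 to compound 3 (1.00 log units; beyond the scatter), so the phenyl ring is not indifferent to substitution at this carbon, and this single added group shifts the number at least as far as the earlier exchange of the whole group did. Measured against the 1H-indol-3-yl group, 4-(trifluoromethyl)phenyl gives a 71-fold higher number from compound 1 to compound 3 (1.85 log units; beyond the scatter), a wider span than a 7.2-fold higher number from compound 1 to compound 2 (0.86 log units; beyond the scatter), and the three compounds now order from 1H-indol-3-yl through phenyl to 4-(trifluoromethyl)phenyl, with compound 3 the weakest inhibitor of the set. Nothing available explains the rise in the number from this change.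

Open, on these data alone, is whether the rise belongs to trifluoromethyl itself or to any group on this carbon; a fluorine, a methoxy group or an amine at the same place would separate the two. Also open, as far as these compounds go, is whether substitution on the 1H-indol-3-yl group of compound 1 would behave as it does on the phenyl ring.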